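The compounds below may be only part of what the source reports. "The series", "measured", "known", "first", "only" and "open" are said of these compounds alone.

Compound 1 `CC(O)(C(=O)Nc1ccc(C(=O)c2ccccc2)cc1F)C(F)(F)F` and compound 2 `CC(O)(C(=O)Nc1ccc(C(=O)c2ccccc2)cc1Cl)C(F)(F)F` share one core and differ only in a halogen on an aromatic carbon. In a functional assay (Cavia porcellus) with sulfonylurea receptors; K-ATP channels (Homo sapiens) as the target (a higher number here means a weaker inhibitor, a lower number a stronger inhibitor), compound 1 gives 11000 nM. In this assay compound 2 gives > 30000 nM, which is a limit of the measurement and not a number. Compound 2 therefore stands at the limit of > 30000 nM in this assay, at which 1 of the 2 values shown sits, the weaker end of what was measured. Among the compounds with values here, the single measured step, an at least 2.7-fold higher number from compound 1 to compound 2 (0.43 log units; beyond the scatter), came with a chloro in place of a fluoro on that aromatic carbon. Compound 3 `CC(O)(C(=O)Nc1ccc(C(=O)c2ccccc2)cc1Br)C(F)(F)F` continues along the same position: bromo in place of chloro on an aromatic carbon. Within the data shown here, the one measured step runs toward weaker inhibition, and no measured step runs the other way, so for the step from compound 2 to compound 3 a small further shift in the same direction, or none beyond the scatter, is expected, as a step that the limit leaves unreadable from compound 2 to compound 3. Compound 3 is accordingly expected near 45000 nM, within a range from 15000 nM to 150000 nM, quite possibly again reported only as a limit.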

Compound 3, half-maximal inhibitory concentration: > 30000 nM
Compound 3: only a limit was reported; the forecaster's own chance of this, stated with the estimate: 65%; the middle value is on the limit's open side.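

With bromo in place of fluoro, an at least 2.7-fold higher number from compound 1 to compound 3 (0.43 log units; beyond the scatter), so in this assay the move away from fluoro at this position now reads the same way for both chloro and bromo, not for chloro alone. This shows that the loss seen with chloro is not unique to that one halogen. The step from chloro to bromo cannot be read, and no order between the two can be given, for compound 2 and compound 3 both end at a limit and not at a number: the limit of > 30000 nM in this assay, at which 2 of the 3 values shown sit.

Still open, on these data alone, is how a plain hydrogen, a methyl or a nitrile on this aromatic carbon would compare with the fluoro of compound 1. Also open, as far as these compounds go, is whether an amine or a carboxylic acid elsewhere on the benzoyl group would shift the inhibition at all.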